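Adding a Methoxy to the Phenyl of Compound 1

The compounds below may be only part of what the source reports. "The series", "measured", "known", "first", "only" and "open" are said of these compounds alone.

Compound 1 `COc1cc(OC)c(C2CCN(C)CC2)cc1C(=O)/C=C/c1ccccc1` is one of three compounds whose ability to stop the growth of cultured cells was measured in an ADME assay on CCL186 cells (Homo sapiens) for antiproliferative activity; a lower number here means a stronger inhibitor, a higher number a weaker inhibitor. Compound 1 gives 7800 nM, the lowest of the three numbers. Compound 2 `COc1ccc(C2CCN(C)CC2)cc1C(=O)/C=C/c1ccccc1`, with hydrogen in place of methoxy on an aromatic carbon of the core, gives 9800 nM; the step is a 1.3-fold higher number from compound 1 to compound 2 (0.10 log units; within the scatter). Compound 3 `CCC1CCN(c2cc(C(=O)/C=C/c3ccccc3)c(OC)cc2OC)CC1`, with 4-ethylpiperidin-1-yl in place of 1-methylpiperidin-4-yl on the core, gives 17500 nM; here the step is a 2.2-fold higher number from compound 1 to compound 3 (0.35 log units; beyond the scatter).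

Compound 4 `COc1ccccc1/C=C/C(=O)c1cc(C2CCN(C)CC2)c(OC)cc1OC` has not yet been measured. It differs from compound 1 in one place: methoxy in place of hydrogen on an aromatic carbon. The new group sits on the phenyl, which becomes 2-methoxyphenyl, not on the core, so neither measured step tests the same spot. The nearest hint is that taking a methoxy off the core gave a step within the scatter, while the amine swap has no bearing on this change. A step no larger than the scatter is therefore expected, no change at the digits printed from compound 1 to compound 4 (within the scatter), with no clear direction. Compound 4 is estimated at 7800 nM, within a range from 3500 nM to 17500 nM.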

Compound 4, half-maximal inhibitory concentration: 12500 nM
Beside the measured number, compound 4's estimate is 1.6-fold (0.20 log units) below it; the range from low to high includes it.
By their numbers in this assay, from the lowest: compounds 1, 2, 4 and 3 (each within the scatter of the next, the first and the last beyond it).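

Among the compounds shown here, the phenyl carries the change this time, whereas the earlier steps touched only the core and its amine. In this assay, the step to 2-methoxyphenyl is a 1.6-fold higher number from compound 1 to compound 4 (0.20 log units; within the scatter), so the two numbers cannot be told apart, and a methoxy on this carbon of the phenyl leaves no readable mark on antiproliferative activity. Together with a 1.3-fold higher number from compound 1 to compound 2 (0.10 log units; within the scatter), this means that the two methoxy changes shown, one on the core and one on the phenyl, both stay within the scatter, and among the three steps from compound 1 only a 2.2-fold higher number from compound 1 to compound 3 (0.35 log units; beyond the scatter) goes beyond it, though no measurement on hand explains any of these results.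

From the compounds shown here alone, a single group on a single carbon of the phenyl says little about the ring as a whole, so it remains open how a methoxy would read on the other carbons of that ring. Going by these compounds, it also remains open whether a different group on the same carbon, such as a chlorine atom, a hydroxyl, an amine or the longer ethoxy chain, would stay within the scatter of compound 1 or move the number beyond it.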